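This account rests on a few compounds, and the source may have more. Where it says the series, first, only, none or still open, it means among the compounds named here.

Measured compounds and their values:

Compound 1, `C#CCCCOc1ccc2oc(=O)c(C(=O)OC)cc2c1`: 1440 nM
Compound 2, `C#CCCCOc1ccc2cc(NC(C)=O)c(=O)oc2c1`: 43.6 nM
Compound 3, `C#CCCCCOc1ccc2oc(=O)c(C(=O)OC)cc2c1`: 123 nM

The three measured compounds were tested in an assay on cells for inhibition of Amine oxidase [flavin-containing] B (Homo sapiens), read by Amplex Red, with stated times of 30 min and 45 min; on this read-out higher numbers stand for weaker inhibition and lower numbers for stronger inhibition. Compound 1 gives 1440 nM in this assay, while compound 3, which carries the change (propargyl in place of ethynyl on a saturated chain carbon, three bonds along the chain from an oxygen on an aromatic ring), gives 123 nM. That single change produced the step of a 12-fold lower number from compound 1 to compound 3 (1.07 log units; beyond the scatter). Compound 2 has the lowest number of the three, 43.6 nM, and sits on a different core from compound 1; the difference between the two cores is not broken down here.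

Compound 4, `C#CCCCCOc1ccc2cc(NC(C)=O)c(=O)oc2c1`, has not yet been measured in this assay. Within the data shown here, it stands to compound 2 as compound 3 stands to compound 1: the change is propargyl in place of ethynyl on a saturated chain carbon, three bonds along the chain from an oxygen on an aromatic ring, the same change as the one made from compound 1 to compound 3, at the same place. Among the measured compounds shown here, whether this change carries the same weight on the core of compound 2 cannot be checked against anything measured, since only one such pair is known. The expectation rests on that single pair, the step of a 12-fold lower number from compound 1 to compound 3 (1.07 log units; beyond the scatter), and on the starting point of compound 2 at 43.6 nM. A somewhat smaller step is expected for compound 4 than was seen before, because compound 2 already gives 43.6 nM as the lowest number seen, giving an expected step of a 5.5-fold lower number from compound 2 to compound 4 (0.74 log units; beyond the scatter). Compound 4 is therefore estimated at 8 nM, within a range from 2.5 nM to 30 nM.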

Compound 4, half-maximal inhibitory concentration: 41.7 nM
For compound 4 the middle estimate is 5.2-fold (0.72 log units) below the measured one, and the stated range ends below it.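

On the core of compound 2, replacing pent-4-yn-1-yl with hex-5-yn-1-yl gave a 1.0-fold lower number from compound 2 to compound 4 (0.02 log units; within the scatter) in this assay, so the clear step seen on the core of compound 1 did not carry over. The same change therefore cannot be treated as having one fixed size in this series, and the two steps differ by more than the usual scatter: the same change on two cores in this assay, a 12-fold lower number (1.07 log units; beyond the scatter) from compound 1 to compound 3 and a 1.0-fold lower number (0.02 log units; within the scatter) from compound 2 to compound 4, 11-fold (1.05 log units) apart, beyond the scatter of two such steps This shows that the result of the change depended on the core in these two matched pairs, but it does not show which difference between the cores is responsible, nor what the change would do on a third core.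

The compounds shown leave open whether a longer chain than hex-5-yn-1-yl would lower the number further on the core of compound 1 or would still make no clear difference on the core of compound 2. They also leave open how the change between these two chains would read if a carboxylic acid or an amine stood in place of the methyl ester or the acetamide group.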